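Fluoro to Trifluoromethyl, Tried Once More on a Second Core

The compounds below may be only part of what the source reports. "The series", "measured", "known", "first", "only" and "open" are said of these compounds alone.

Three compounds have been measured in a functional assay on the whole organism (strain Swiss) with Mus musculus as the target, in the maximal electroshock model, with a stated time of 2 h, at a dose of 300 mg/kg by the intraperitoneal route; a higher number here means a stronger effect of the compound at the dose given, a lower number a weaker effect:
compound 1 `CC(C(=O)N1CCN(c2ccccc2F)CC1)N1C(=O)CCC1=O`, which gives 25%
compound 2 `CCC(C(=O)N1CCN(c2ccc(C(F)(F)F)cc2)CC1)N1C(=O)CCC1=O`, which gives 0%
compound 3 `CCC(C(=O)N1CCN(c2ccc(F)cc2)CC1)N1C(=O)CCC1=O`, which gives 0%

Compound 1 stands highest of the three, beyond the scatter from both others. Between compound 3 and compound 2 the change is trifluoromethyl in place of fluoro on an aromatic carbon, and the step is no change at the digits printed from compound 3 to compound 2 (within the scatter). How the core of compound 1 differs from that of compound 3 is not broken down here.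

Compound 4 `CC(C(=O)N1CCN(c2ccccc2C(F)(F)F)CC1)N1C(=O)CCC1=O` is the unmeasured member. It differs from compound 1 by trifluoromethyl in place of fluoro on an aromatic carbon, the same kind of change as from compound 3 to compound 2, though there the new group sat para to a large group and here it sits ortho to one. Since the earlier step of no change at the digits printed from compound 3 to compound 2 (within the scatter) started from a floor of nothing, it says little about a compound that does act; the expected step is therefore a cautious a number 5 percentage points lower from compound 1 to compound 4 (within the scatter). Compound 4 is estimated at 20%, between 0% and 50%.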

Compound 4, a percentage reported as activity, at one dose (the size of the read-out at that dose, not a potency): 75%
Beside the measured number, compound 4's estimate is 55 percentage points below it; the whole stated range lies below it.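

In this assay, trifluoromethyl in place of fluoro on an aromatic carbon gives a number 50 percentage points higher from compound 1 to compound 4 (beyond the scatter), so the change did not carry from one core to the other with the same outcome: the same change on two cores in this assay, no change at the digits printed (within the scatter) from compound 3 to compound 2 and a number 50 percentage points higher (beyond the scatter) from compound 1 to compound 4, 50 percentage points apart, beyond the scatter of two such steps

The two steps differ in more than the core, as the trifluoromethyl of compound 4 stands ortho to a large group, a place it does not hold in compound 2. The steps therefore cannot show whether the core or the place of the group sets the gap between them.

Still open, going by these compounds, is whether a chloro or a methoxy group in that same place would act like trifluoromethyl. Also open, on these data alone, is how the core of compound 3 would respond with trifluoromethyl ortho to a large group.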